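Methoxy for Methyl on a Second Core

The source may hold more compounds than are shown below. What is called first, only, known or untested is meant among the compounds shown, and "the series" means these compounds.

Compound 1 `CCOC(=O)c1csc2nc(CN3CCN(C)CC3)c(-c3ccc(C)cc3)n12` and compound 2 `CCOC(=O)c1csc2nc(CN3CCN(C)CC3)c(-c3ccc(OC)cc3)n12` share one core and differ only in methoxy in place of methyl on an aromatic carbon. In a functional assay on HeLa cells (Homo sapiens) for antiproliferative activity, read by MTT assay, with a stated time of 72 h (a higher number here means a weaker inhibitor, a lower number a stronger inhibitor), compound 1 gives 43900 nM, and compound 2 gives 35100 nM. Compound 3 `CC(=O)NNC(=O)c1csc2ncc(-c3ccc(C)cc3)n12` is built on a different core; how its core differs from that of compound 1 is not broken down here. In this assay compound 3 gives 74200 nM. Compound 4 `COc1ccc(-c2cnc3scc(C(=O)NNC(C)=O)n23)cc1` is to compound 3 what compound 2 is to compound 1: it carries methoxy in place of methyl on an aromatic carbon, and the place of the change reads the same in both pairs, so this is the same change made on a second core. The change has been measured only once, in the step of a 1.3-fold lower number from compound 1 to compound 2 (0.10 log units; within the scatter), which stays within the scatter, so the step of a 1.3-fold lower number from compound 3 to compound 4 (0.11 log units; within the scatter) is expected to be of a similar, small size. On that basis compound 4 is estimated at 57000 nM in this assay, with a range from 25000 nM to 130000 nM.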

Compound 4, half-maximal inhibitory concentration: 17900 nM
Beside the measured number, compound 4's estimate is 3.2-fold (0.50 log units) above it; measured number outside the range, below it.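

In this assay, methoxy in place of methyl on an aromatic carbon gives a 4.1-fold lower number from compound 3 to compound 4 (0.62 log units; beyond the scatter), so on this second core the change brings a step that stands clear of the scatter. Set beside the first pair, the change does not carry over at one fixed size, and the core it sits on appears to matter: the same change on two cores in this assay, a 1.3-fold lower number (0.10 log units; within the scatter) from compound 1 to compound 2 and a 4.1-fold lower number (0.62 log units; beyond the scatter) from compound 3 to compound 4, 3.3-fold (0.52 log units) apart, beyond the scatter of two such steps. The number falls in both pairs, but two pairs are too few to set a rule, and they cannot tell which of the differences between the two cores goes with the larger step, or why the size differs.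

The compounds shown leave open whether other groups on that same aromatic carbon, such as a chlorine atom, an ethoxy group or an amine, would also follow the core in this way. They also leave open how the change would behave on a core carrying a carboxylic acid where compound 1 has its ethyl ester.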